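This account rests on a few compounds, and the source may have more. Where it says the series, first, only, none or still open, it means among the compounds named here.

In a functional assay on the whole organism for antagonist activity, with Mus musculus as the target (a higher number here means that more compound is needed for the effect, a lower number that less compound is needed), compound 3 `CCC(CC)CN1CCC(C(=O)Nc2cc(Cl)c(N)cc2OC)CC1` reaches only a limit, > 10 mg/kg. Compound 1 `COc1cc(N)c(Cl)cc1NC(=O)C1CCN(Cc2cccc(C#N)c2)CC1` also stops at a limit in this assay, > 4 mg/kg. Compound 2 `COc1cc(N)c(Cl)cc1NC(=O)C1CCN(Cc2ccc([N+](=O)[O-])cc2)CC1` likewise ends at a limit in this assay, > 4 mg/kg. Compound 3 therefore stands at the limit of > 10 mg/kg in this assay, at which 1 of the 3 values shown sits. Compound 1 and compound 2 sit at the limit of > 4 mg/kg in this assay, at which 2 of the 3 values shown sit, so none of the three values shown is a number. The change to compound 4 `COc1cccc(CN2CCC(C(=O)Nc3cc(Cl)c(N)cc3OC)CC2)c1` is 3-methoxyphenyl in place of pentan-3-yl on a saturated chain carbon bound to an amine nitrogen in a ring. The measured steps that bear on it are a step that the two limits leave unreadable from compound 1 to compound 3 and a step that the two limits leave unreadable from compound 2 to compound 3, and a step that the two limits leave unreadable from compound 1 to compound 2 adds nothing more, since every one of them runs between two limits and its size cannot be read. What remains is that both compounds carrying an aromatic ring at this place, compound 1 and compound 2, ended at a limit. Compound 4 is expected to give 8 mg/kg, within 3 mg/kg to 30 mg/kg, most probably again as a limit. The step expected in this assay is an at least 1.2-fold lower number from compound 3 to compound 4 (0.09 log units; that floor lies within the scatter).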

Compound 4, dose for half-maximal effect: > 4 mg/kg
Compound 4: no number, only a limit; the forecaster's own chance of this, stated with the estimate: 70%; the middle value lies beyond the limit too.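

Compound 4 ends at a limit in this assay, > 4 mg/kg. Among the compounds shown here, no step among compound 1, compound 2, compound 3 and compound 4 can be read. The compounds shown leave open whether any of these groups on the shared core gives an actual number in this assay.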